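The source may report more compounds than this note shows. Statements on the series, on what has been measured and on what is new or still open speak of the compounds shown alone.

Measured compounds:
- compound 1 `COc1ccc2oc(/C=C/c3ccc(OC(F)(F)F)cc3)cc(=O)c2c1`, in a functional assay on A549 cells (Homo sapiens) for antiproliferative activity, read by MTT assay, with a stated time of 12 h (a lower number here means a stronger inhibitor, a higher number a weaker inhibitor), compound 1 gives > 40000 nM, which is a limit of the assay rather than a number
- compound 2 `COc1cc(OC)c2c(=O)cc(/C=C/c3ccncc3)oc2c1`, in this assay compound 2 gives > 40000 nM, again a limit and not a number

Both measured compounds therefore stand at the same place: the limit of > 40000 nM in this assay, at which 2 of the 2 values shown sit. Compound 2 is not ranked against compound 1 by these results; neither shows a measurable value, and nothing separates them on the numbers shown.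

The unmeasured compound 3 `COc1cc(OC)c2c(=O)cc(/C=C/c3ccccc3)oc2c1` shares the core of compound 2 and differs in one place: phenyl in place of pyridin-4-yl on a double-bonded chain carbon bound to a double-bonded chain carbon. Among the measured compounds shown here, no measured pair shows what this change does here, so no step can be read from the data.

With compound 2 sitting at a limit, the expectation for compound 3 is that this assay most likely again reports a limit, or at best a weak value close to it. The step from compound 2 to compound 3 is expected to be a number no higher from compound 2 to compound 3 (the limit leaves the size open), which is to say no clear change beyond the scatter. Compound 3 is estimated at 40000 nM, within a range from 10000 nM to 150000 nM.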

Compound 3, half-maximal inhibitory concentration: 21500 nM
Estimate against measurement, compound 3: 1.9-fold (0.27 log units) above; low and high end bracket the measured number.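

Among the compounds shown here, compound 3 gives the first real number at this position in this assay, so the place named here, a double-bonded chain carbon bound to a double-bonded chain carbon, can now be read, and putting phenyl in place of pyridin-4-yl gives an at least 1.8-fold lower number from compound 2 to compound 3 (0.26 log units; that floor lies within the scatter). Compound 2 gives > 40000 nM, which is a limit and not a number. The step is therefore only a floor, so the true gap could be larger, but what is printed does not go beyond the scatter, and limits still make up most of what can be seen in this series: the limit of > 40000 nM in this assay, at which 2 of the 3 values shown sit.

From the compounds shown here alone, compound 1 differs from compound 3 in more than one place, so no step can be read between them, and the effect of the other groups on the shared core stays unknown. Going by these compounds, it also remains open whether a different group in this same place, such as a phenyl ring carrying an amine or a carboxylic acid, would give a number clearly lower than that of compound 3.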